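Removing a methyl from an aryl methoxy group

A few compounds are considered here, and "the series" means these few. Any claim that something is new, unique, unknown or untested is made for them only; others in the source may bear on it.

Two pyrazole ureas have been tested so far in a functional assay on HCT-15 cells (Homo sapiens) for inhibition, read by sulforhodamine B assay, with a stated time of 48 h; on this read-out lower numbers stand for stronger inhibition of growth and higher numbers for weaker inhibition of growth. Compound 1 `O=C(Nc1cccc(-n2cc(-c3ccncc3)c(-c3ccc(Cl)c(O)c3)n2)c1)Nc1cccc(C(F)(F)F)c1` gives 1510 nM in this assay. Compound 2 `COc1cc(-c2nn(-c3cccc(NC(=O)Nc4cc(C(F)(F)F)cc(C(F)(F)F)c4)c3)cc2-c2ccncc2)ccc1Cl` gives 617 nM, the lowest of the two numbers; compound 1 sits at a higher number, and the gap between them is beyond the usual scatter. The two compounds differ in more than one place, so no single change can be read from that gap.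

Compound 3 `O=C(Nc1cccc(-n2cc(-c3ccncc3)c(-c3ccc(Cl)c(O)c3)n2)c1)Nc1cc(C(F)(F)F)cc(C(F)(F)F)c1` differs from compound 2 in one place only: hydrogen in place of methyl on an oxygen on an aromatic ring, that is, methoxy becomes hydroxy on the 4-chloro-3-methoxyphenyl ring, giving 4-chloro-3-hydroxyphenyl. Within the data shown here, no measured pair isolates this change, so its effect is unknown. A modest change, in either direction, seems the most plausible expectation, with the step of a 1.2-fold higher number from compound 2 to compound 3 (0.08 log units; within the scatter) expected to stay close to the scatter. Compound 3 is therefore estimated at 750 nM, within a range from 250 nM to 2200 nM.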

Compound 3, concentration for 50% growth inhibition: 474 nM
Estimate against measurement, compound 3: 1.6-fold (0.20 log units) above; the range from low to high includes it.
By their numbers in this assay, from the lowest: compounds 3 and 2 (each within the scatter of the next); then compound 1.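

On an oxygen on an aromatic ring, hydrogen can take the place of methyl with no readable shift in this assay (a 1.3-fold lower number from compound 2 to compound 3 (0.11 log units; within the scatter)), so this position accepts either methoxy or hydroxy here. Trifluoromethyl in place of hydrogen on an aromatic carbon does give a clear step (a 3.2-fold lower number from compound 1 to compound 3 (0.50 log units; beyond the scatter)), and it is the only single-place change shown that lies beyond the scatter. Nothing available explains either step.

On these data alone, whether this oxygen also accepts something larger, such as an ethyl group or a longer chain, remains open, as does replacing the hydroxy with an amine. It is also unknown whether methoxy and hydroxy would still match on a compound carrying the urea end of compound 1.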